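A few compounds are considered here, and "the series" means these few. Any claim that something is new, unique, unknown or untested is made for them only; others in the source may bear on it.

Measured so far:
Compound 1 `Cc1cccc(OS(=O)(=O)c2ccc(N3CCN(C)C3=O)cc2)c1` gives 4300 nM in a functional assay on HT-29 cells (Homo sapiens) for antiproliferative activity, read by sulforhodamine B assay, with a stated time of 48 h; a lower number here means a stronger inhibitor, a higher number a weaker inhibitor.
Compound 2 `COc1cccc(OS(=O)(=O)c2ccc(N3CCN(C)C3=O)cc2)c1` gives 2500 nM in this assay.
Compound 3 `CCCN1CCN(c2ccc(S(=O)(=O)Oc3cccc(C)c3)cc2)C1=O` gives 65000 nM in this assay.

Compound 2 differs from compound 1 by one change, (methoxy in place of methyl on an aromatic carbon), and the step is a 1.7-fold lower number from compound 1 to compound 2 (0.24 log units; within the scatter). Compound 3 carries a different core, (ethyl in place of hydrogen on a saturated chain carbon bound to an amide-type nitrogen in a ring), and that change makes a large step, a 15-fold higher number from compound 1 to compound 3 (1.18 log units; beyond the scatter). Compound 4 `CCCN1CCN(c2ccc(S(=O)(=O)Oc3cccc(OC)c3)cc2)C1=O` is compound 3 with the same change that turned compound 1 into compound 2: methoxy in place of methyl on an aromatic carbon, at the same kind of place in both pairs.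

In this assay the step from compound 3 to compound 4 is expected to be a 1.6-fold lower number from compound 3 to compound 4 (0.21 log units; within the scatter), resting on the earlier step of a 1.7-fold lower number from compound 1 to compound 2 (0.24 log units; within the scatter) and on the value of compound 3, 65000 nM. Compound 4 is therefore estimated at 40000 nM, between 15000 nM and 110000 nM.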

Compound 4, half-maximal inhibitory concentration: 25000 nM
Compound 4: middle estimate off by 1.6-fold (0.20 log units), on the high side; the range from low to high includes it.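

In this assay, methoxy in place of methyl gives a 2.6-fold lower number from compound 3 to compound 4 (0.41 log units; beyond the scatter), and this step matches the earlier one on the other core: the same change on two cores in this assay, a 1.7-fold lower number (0.24 log units; within the scatter) from compound 1 to compound 2 and a 2.6-fold lower number (0.41 log units; beyond the scatter) from compound 3 to compound 4, 1.5-fold (0.18 log units) apart, within the scatter of two such steps. The ethyl in place of hydrogen on the chain gives a 10-fold higher number from compound 2 to compound 4 (1.00 log units; beyond the scatter), and this change also carries over: the same change on two cores in this assay, a 15-fold higher number (1.18 log units; beyond the scatter) from compound 1 to compound 3 and a 10-fold higher number (1.00 log units; beyond the scatter) from compound 2 to compound 4, 1.5-fold (0.18 log units) apart, within the scatter of two such steps. Across these four compounds the two changes therefore behave as if independent of each other, but this rests on only two pairs of steps in one assay and does not show why they do so or that they would on any other core.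

On these data alone, it remains open whether an amine or a carboxylic acid on that aromatic carbon would carry over in the same way. As far as these compounds go, a butyl chain in place of the propyl chain of compound 3 and compound 4 is equally open.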